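A few compounds are considered here, and "the series" means these few. Any claim that something is new, unique, unknown or untested is made for them only; others in the source may bear on it.

Working notes on the series. In an ADME assay on S9 fraction from lung (Homo sapiens) for metabolic stability, read by LC-MS, using NADPH, with a stated time of 60 min, tested at 1 uM (a higher number here means that more of the compound is left, a lower number that less of the compound is left), compound 1 `COc1ccc(S(=O)(=O)N2CCC[C@H]2C(=O)O[C@@H](Cc2c(Cl)c[n+]([O-])cc2Cl)c2ccc(OC(F)F)c(OCC3CC3)c2)cc1C(=O)N(C)C` gives 71.6%, and compound 2 `COc1ccc(S(=O)(=O)N2CCCC[C@H]2C(=O)O[C@@H](Cc2c(Cl)c[n+]([O-])cc2Cl)c2ccc(OC(F)F)c(OCC3CC3)c2)cc1C(=O)N(C)C` gives 59.7%. Compound 2 is therefore the lower of the two measured compounds, and its gap to compound 1 lies beyond the scatter.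

The next compound to be measured is compound 3 `CN(C)C(=O)c1cccc(S(=O)(=O)N2CCCC[C@H]2C(=O)O[C@@H](Cc2c(Cl)c[n+]([O-])cc2Cl)c2ccc(OC(F)F)c(OCC3CC3)c2)c1`. It differs from compound 2 in one place: hydrogen in place of methoxy on an aromatic carbon. Hydrogen stands in place of methoxy on an aromatic carbon, ortho to a dimethylcarbamoyl group and para to a large group.

Among the measured compounds shown here, no measured pair shows this change, so the data give no direct guide to its size or direction. For the measured compounds named here, the only starting point is compound 2 at 59.7%, and a step beyond the scatter is not expected in either direction. The estimated change is a number 1.7 percentage points lower from compound 2 to compound 3 (within the scatter), which is expected to stay within the scatter. The range is kept wide to reflect the lack of a measured precedent. In this assay the expected value for compound 3 is 58%, with an estimated range from 42% to 74%.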

Compound 3, percent of the compound remaining: 72.5%
Estimate against measurement, compound 3: 14.5 percentage points below, and the stated range covers the measured number.
By their numbers in this assay, from the lowest: compound 2; then compounds 1 and 3 (each within the scatter of the next).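

In this assay, hydrogen in place of methoxy on an aromatic carbon, ortho to a dimethylcarbamoyl group and para to a large group, gives a number 12.8 percentage points higher from compound 2 to compound 3 (beyond the scatter). The earlier compounds shown here both carry the methoxy on this carbon, so they could not show whether this position bears on the percent of compound remaining; this step shows that it does, with more of the compound left once the methoxy is gone, so far on a single background. Nothing at hand bears on why the read-out moves with this change.

On these data alone, whether the same step appears on the background of compound 1 remains open, as one pair gives the size and direction of this change in a single setting only. Also open, as far as these compounds go, is whether the step follows from losing the methoxy or would hold for other groups on this carbon, such as fluorine, hydroxyl, ethoxy or an amine, and whether the dimethylcarbamoyl group takes any part, which a primary amide or a carboxylic acid in its place could test.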